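The source may report more compounds than this note shows. Statements on the series, on what has been measured and on what is new or still open speak of the compounds shown alone.

In a functional assay on SK-N-MC cells (Homo sapiens) for cytotoxicity, read by MTT assay, with a stated time of 72 h (a higher number here means a weaker inhibitor, a lower number a stronger inhibitor), compound 1 `O=c1[nH]c(/C=C/c2ccccc2)nc2ccccc12` gives 1390 nM and compound 2 `COc1ccccc1/C=C/c1nc2ccccc2c(=O)[nH]1` gives 2880 nM, the higher of the two numbers and so the weaker inhibitor of the pair. Compound 3 `O=c1[nH]c(/C=C/c2ccccc2Br)nc2ccccc12` has bromo in place of methoxy on an aromatic carbon, on a six-membered aromatic ring of carbon only, ortho to a large group (bromo in place of methoxy on an aromatic carbon). Within the data shown here, only one measured step bears on this change: methoxy in place of hydrogen on an aromatic carbon gave a 2.1-fold higher number from compound 1 to compound 2 (0.32 log units; beyond the scatter), which is modest. Among the measured compounds shown here, no measured compound carries bromo, so this evidence is indirect. A modest move back toward compound 1 is expected, possibly no larger than the scatter. The expected change is a 1.4-fold lower number from compound 2 to compound 3 (0.16 log units; within the scatter). For compound 3 the estimated value is 2000 nM, with an expected range from 800 nM to 5000 nM.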

Compound 3, half-maximal inhibitory concentration: > 6250 nM
Compound 3: a limit, no number; the forecaster's own chance of this, stated with the estimate: 3%; at least 3.1-fold (0.49 log units) between middle value and limit.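

For compound 3 the result in this assay is a limit of the assay, not a number: the limit of > 6250 nM in this assay, at which 1 of the 3 values shown sits. Bromo in place of methoxy gives an at least 2.1-fold higher number from compound 2 to compound 3 (0.33 log units; beyond the scatter), and bromo in place of hydrogen gives an at least 4.4-fold higher number from compound 1 to compound 3 (0.65 log units; beyond the scatter). The earlier pair showed only that methoxy on this aromatic carbon, ortho to a large group, goes with a higher number than hydrogen; this result shows that the two groups are not interchangeable here, with bromo moving the number further from compound 1, not back toward it.

As far as these compounds go, how far the value of compound 3 lies past its limit stays open, so both steps are known from one side only. Also open, from the compounds shown here alone, is whether fluoro, an amine or a hydroxyl on this same carbon would raise the number from compound 1 too.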